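Swapping the Aminoethyl Tail for Isopropyl on a Weak Binder

The source may report more compounds than this note shows. Statements on the series, on what has been measured and on what is new or still open speak of the compounds shown alone.

Of the compounds shown here, three built on a shared core have been tested in an assay for inhibition of Tryptophan 2,3-dioxygenase (Homo sapiens), with stated times of 10 min and 60 min; on this read-out lower numbers stand for stronger inhibition and higher numbers for weaker inhibition. Compound 1, `Oc1ccc(CNc2cc(C(F)(F)F)cc3[nH]ncc23)cc1`, carries a hydroxyphenyl methylamino group and gives 2550 nM in this assay. Compound 2, `NCCn1ncc2c(NCc3ccccc3[N+](=O)[O-])cc(C(F)(F)F)cc21`, carries a nitrophenyl methylamino group together with a 2-aminoethyl chain on its ring nitrogen. In this assay compound 2 reaches only the limit of the measurement, > 100000 nM, so no true number is known for it. Compound 3, `FC(F)(F)c1cc(NCc2cccc3sccc23)c2cn[nH]c2c1`, likewise reaches only a limit, > 100000 nM, in this assay. Compound 2 thus sits at the limit of > 100000 nM in this assay, at which 2 of the 3 values shown sit.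

Compound 4, `CC(C)n1ncc2c(NCc3ccccc3[N+](=O)[O-])cc(C(F)(F)F)cc21`, has not yet been measured. It differs from compound 2 in one place: isopropyl in place of 2-aminoethyl on an aromatic nitrogen. Within the data shown here, no measured pair shows this kind of change, so its effect cannot be read from the numbers at hand. Because compound 2 shows only > 100000 nM, any expectation for compound 4 must start from that limit. The step is expected to be an at least 1.2-fold lower number from compound 2 to compound 4 (0.09 log units; that floor lies within the scatter), a modest move toward stronger inhibition that may still leave the result at a limit. Compound 4 is expected to give about 80000 nM, within a range from 20000 nM to 300000 nM.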

Compound 4, half-maximal inhibitory concentration: > 100000 nM
Compound 4 was reported as a limit; the forecaster's own chance of this, stated with the estimate: 55%; at least 1.2-fold (0.09 log units) between middle value and limit.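

In this assay, compound 2 and compound 4 both stand at a limit rather than at a true number, so no step between them can be read: the limit of > 100000 nM in this assay, at which 3 of the 4 values shown sit.

The compounds shown leave open how isopropyl and 2-aminoethyl on the aromatic nitrogen truly compare, and what real number lies behind either limit.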